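From Acetamido to Benzamido: What to Expect of Compound 4

This account rests on a few compounds, and the source may have more. Where it says the series, first, only, none or still open, it means among the compounds named here.

Measured in a functional assay on KB cells (Homo sapiens) for inhibition; on this read-out lower numbers stand for stronger inhibition and higher numbers for weaker inhibition:
Compound 1, `CCOC(c1ccc(OC)cc1)c1ccc(C(C)C)cc(=O)c1O`: 0.5 ug/mL
Compound 2, `O=C1c2ccccc2CCC1C1OCCc2ccccc21`: 42 ug/mL
Compound 3, `COc1ccc(C(NC(C)=O)c2ccc(C(C)C)cc(=O)c2O)cc1`: 6 ug/mL

Compound 3 stands second highest of the three numbers in this assay. Going by the values given here, compound 2 shows a higher number than compound 3, and the single one-place step, a 12-fold higher number from compound 1 to compound 3 (1.08 log units; beyond the scatter), sets compound 1 well below it. Compound 4, `COc1ccc(C(NC(=O)c2ccccc2)c2ccc(C(C)C)cc(=O)c2O)cc1`, differs from compound 3 by phenyl in place of methyl on a carbonyl carbon. Among the compounds with values here, no measured step bears directly on this change: the only step at this part of the molecule, a 12-fold higher number from compound 1 to compound 3 (1.08 log units; beyond the scatter), exchanges the whole group rather than enlarging the acetyl. The step in this assay is therefore expected to stay within the scatter, in either direction, no change at the digits printed from compound 3 to compound 4 (within the scatter). Compound 4 is estimated at 6 ug/mL, with a range from 2 ug/mL to 18 ug/mL.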

Compound 4, concentration for 50% inhibition: 1.7 ug/mL
Beside the measured number, compound 4's estimate is 3.5-fold (0.55 log units) above it; measured number outside the range, below it.
By their numbers in this assay, from the lowest: compound 1; then compound 4; then compound 3; then compound 2.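

In this assay, going by these compounds alone, the group on the carbonyl carbon proves to matter: acetyl to benzoyl gives a 3.5-fold lower number from compound 3 to compound 4 (0.55 log units; beyond the scatter), which the earlier compounds, with only acetamido at this place, could not show. Benzamido takes back only part of the ground lost with acetamido, as ethoxy still stays ahead, with a 3.4-fold higher number from compound 1 to compound 4 (0.53 log units; beyond the scatter). Nothing on hand explains this step. The compounds shown leave open whether the step follows from the aromatic ring or simply from the added carbons: cyclohexyl or a longer chain on that carbonyl carbon would separate the two.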